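Replacing the hydrazone aryl group in a cytotoxicity series

This account rests on a few compounds, and the source may have more. Where it says the series, first, only, none or still open, it means among the compounds named here.

Compound 1, `COc1cc2c(Oc3ccc(NC(=O)N/N=C/c4ccc(OC(F)(F)F)cc4)cc3F)ccnc2cc1OCCCN1CCCCC1`: 820 nM
Compound 2, `COc1cc2c(Oc3ccc(NC(=O)N/N=C/c4ccc(O)cc4)cc3F)ccnc2cc1OCCCN1CCCCC1`: 790 nM

Of the compounds shown here, two sharing one core have been measured. In a functional assay on MDA-MB-231 cells (Homo sapiens) for cytotoxicity, read by MTT assay, with a stated time of 72 h (a lower number here means a stronger inhibitor, a higher number a weaker inhibitor), compound 1 gives 820 nM, and in this assay compound 2 gives 790 nM. Among the compounds with values here, compound 2 stands next to compound 1, the only other measured compound, and the step of a 1.0-fold lower number from compound 1 to compound 2 (0.02 log units; within the scatter) separates them, so the two numbers cannot be told apart.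

Compound 3, `C=CCc1cccc(/C=N/NC(=O)Nc2ccc(Oc3ccnc4cc(OCCCN5CCCCC5)c(OC)cc34)c(F)c2)c1OC`, is not yet measured. It differs from compound 2 in one place: 3-allyl-2-methoxyphenyl in place of 4-hydroxyphenyl on a carbon with a double bond to nitrogen. Within the data shown here, the only measured step that bears on this is the one from compound 1 to compound 2, which changed the same aryl group, on the same carbon, and was a 1.0-fold lower number from compound 1 to compound 2 (0.02 log units; within the scatter). Among the measured compounds shown here, that change was a small one, and the present one replaces the whole aryl group, so the single prior step is a weak guide. With nothing in the data pointing either way, the expected step of a 1.1-fold higher number from compound 2 to compound 3 (0.03 log units; within the scatter) is none beyond the scatter, with a wide range. Compound 3 is therefore estimated at 850 nM, between 250 nM and 3000 nM.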

Compound 3, half-maximal inhibitory concentration: 790 nM
Beside the measured number, compound 3's estimate is 1.1-fold (0.03 log units) above it; the measured number falls inside the stated range.
By their numbers in this assay, from the lowest: compounds 2, 3 and 1 (each within the scatter of the next).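

In this assay, the step of no change at the digits printed from compound 2 to compound 3 (within the scatter) shows that the aryl group on this carbon with a double bond to nitrogen can be exchanged for a clearly larger one without a change beyond the scatter: 3-allyl-2-methoxyphenyl has 11 heavy atoms against 7 in 4-hydroxyphenyl, and it carries no hydrogen-bond donor and adds a double bond outside aromatic rings. The step of a 1.0-fold lower number from compound 1 to compound 3 (0.02 log units; within the scatter) gives the same reading against 4-(trifluoromethoxy)phenyl, so all three aryl groups now give numbers that cannot be told apart, whereas the earlier pair differed only in the group on an oxygen on an aromatic ring. No measurement shown here explains this insensitivity to the aryl group.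

Because the allyl and methoxy groups entered together, the compounds shown cannot separate what each contributes, so a phenyl ring carrying only one of them would be needed for that comparison. They also leave open whether this tolerance extends to an aryl group carrying a carboxylic acid or a primary amine, or to a small alkyl chain in place of the aromatic ring.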